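This account rests on a few compounds, and the source may have more. Where it says the series, first, only, none or still open, it means among the compounds named here.

- compound 1 `O=C(Cc1csc2nc(-c3ccc(Br)cc3)cn12)N/N=C/c1ccccc1`: 39800 nM
- compound 2 `O=C(Cc1csc2nc(-c3ccc(Br)cc3)cn12)N/N=C/c1ccccc1O`: 15800 nM
- compound 3 `O=C(Cc1csc2nc(-c3ccc(Br)cc3)cn12)N/N=C/c1ccc(O)cc1`: not yet measured

Among the measured compounds shown here, in a functional assay on SN12C cells (Homo sapiens) for inhibition, read by sulforhodamine B assay, with a stated time of 48 h (on this read-out lower numbers stand for stronger inhibition of growth and higher numbers for weaker inhibition of growth), compound 2, at 15800 nM, holds the lower of the two numbers, with compound 1 the only neighbour. The next change is 4-hydroxyphenyl in place of 2-hydroxyphenyl on a carbon with a double bond to nitrogen. For the measured compounds named here, the only measured step that bears on it is the modest 2.5-fold lower number from compound 1 to compound 2 (0.40 log units; beyond the scatter), which introduced the hydroxy group. Going by the values given here, compound 3 keeps that hydroxy group, and no measured compound shows what its new place does. The expected step, a 1.3-fold higher number from compound 2 to compound 3 (0.10 log units; within the scatter), is therefore small, slightly upward and within the scatter. For compound 3 the estimated value is 20000 nM, with an expected range of 8000 nM to 45000 nM.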

Compound 3, concentration for total growth inhibition: 43700 nM
Estimate against measurement, compound 3: 2.2-fold (0.34 log units) below; the range from low to high includes it.
By their numbers in this assay, from the lowest: compound 2; then compounds 1 and 3 (each within the scatter of the next).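

In this assay the place of the hydroxy group matters: 4-hydroxyphenyl in place of 2-hydroxyphenyl gives a 2.8-fold higher number from compound 2 to compound 3 (0.44 log units; beyond the scatter) and so moves beyond the scatter. Set against the unsubstituted phenyl of compound 1, the 4-hydroxyphenyl group gives a 1.1-fold higher number from compound 1 to compound 3 (0.04 log units; within the scatter) and thus no readable change, so the lower number seen with 2-hydroxyphenyl does not carry over to 4-hydroxyphenyl. No available evidence accounts for this difference between the two placements.

As far as these compounds go, whether methoxy or an amine on the same ring would follow the 2-hydroxyphenyl or the 4-hydroxyphenyl result remains open.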